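The source may hold more compounds than are shown below. What is called first, only, known or untested is meant among the compounds shown, and "the series" means these compounds.

In a functional assay on DU-145 cells (Homo sapiens) for cytotoxicity, read by XTT assay, with a stated time of 24 h (on this read-out higher numbers stand for weaker inhibition and lower numbers for stronger inhibition), compound 1 `CC(=O)Oc1cc(OC(C)=O)c2c(OC(C)=O)cc(C)c(Cl)c2c1OC(C)=O` gives 59600 nM while compound 2 `CC(=O)Oc1cc(C)c(Cl)c2c1C(=O)C=CC2=O` gives 25500 nM and compound 3 `COc1cc(C)c(Cl)c2c1C(=O)C=CC2=O` gives 26600 nM as its result. Compound 3 therefore sits level with compound 2, within the usual scatter, and clearly lower than compound 1 on this scale, where lower means stronger inhibition.

Compound 4 `Cc1cc(O)c2c(c1Cl)C(=O)C=CC2=O` differs from compound 3 by a single change hydrogen in place of methyl on an oxygen on an aromatic ring in which hydrogen takes the place of methyl on an oxygen on an aromatic ring, turning methoxy to hydroxy. Within the data shown here, the one measured step at this oxygen is a 1.0-fold higher number from compound 2 to compound 3 (0.02 log units; within the scatter) for methyl in place of acetyl, and it lies within the scatter. Among the measured compounds shown here, no measured compound carries hydroxy there, so this guidance is thin. Going by that step, no clear shift is expected in this assay for this change. The estimated step is a 1.5-fold lower number from compound 3 to compound 4 (0.17 log units; within the scatter) and so stays within the scatter. Compound 4 is estimated at 18000 nM with an expected range of 7000 nM to 35000 nM for now.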

Compound 4, half-maximal inhibitory concentration: 29500 nM
Compound 4: middle estimate off by 1.6-fold (0.21 log units), on the low side, within the range that was stated.
By their numbers in this assay, from the lowest: compounds 2, 3 and 4 (each within the scatter of the next); then compound 1.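

Compound 4 is the first compound shown with a free hydroxy on this oxygen on an aromatic ring, and in this assay the change from methoxy to hydroxy gives little movement (a 1.1-fold higher number from compound 3 to compound 4 (0.04 log units; within the scatter)). Hydrogen in place of acetyl on the same oxygen also stays small (a 1.2-fold higher number from compound 2 to compound 4 (0.06 log units; within the scatter)), so acetyl, methyl and hydrogen at this place all read alike, and none of the three can be told apart from the others here. Nothing available explains why these three groups read alike.

Going by these compounds, whether a longer chain such as butyl on this oxygen, or an amine in its place, would move the number beyond the scatter remains open. The compounds shown also leave open whether the other groups on the shared core matter more than this one.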